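Working notes on the methoxy to hydrogen step

This account rests on a few compounds, and the source may have more. Where it says the series, first, only, none or still open, it means among the compounds named here.

Measured so far in a physicochemical assay for solubility, in phosphate buffer, at pH 7.4; on this read-out higher numbers stand for higher solubility and lower numbers for lower solubility
- compound 1 `COC(=O)c1ccc(CNC(=O)C2CCc3ccccc3C2)cc1` gives 125000 nM
- compound 2 `COC(=O)c1ccc(CNC(=O)c2ccc3cc(OC)ccc3c2)cc1` gives 15000 nM

Compound 2 holds the lower of the two numbers, and compound 1 stands higher by a margin beyond the scatter. These two compounds differ in more than one place, so their gap does not inform the step considered here. Compound 3 `COC(=O)c1ccc(CNC(=O)c2ccc3ccccc3c2)cc1` is the next to be read. Its difference from compound 2 is hydrogen in place of methoxy on an aromatic carbon and amounts to hydrogen in place of methoxy on an aromatic carbon. Within the data shown here, no measured pair shows this change. In this assay no step beyond the scatter is expected, and any upward drift should be slight. The estimated 1.3-fold higher number from compound 2 to compound 3 (0.12 log units; within the scatter) is expected to stay within the scatter. The estimate for compound 3 is 20000 nM (range 6000 nM to 60000 nM).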

Compound 3, solubility: 31000 nM
For compound 3 the middle estimate is 1.6-fold (0.19 log units) below the measured one, and the stated range covers the measured number.
By their numbers in this assay, from the lowest: compound 2; then compound 3; then compound 1.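

In this assay, among these compounds, hydrogen in place of methoxy on an aromatic carbon gives a 2.1-fold higher number from compound 2 to compound 3 (0.32 log units; beyond the scatter), the first reading of this change in a pair differing in one place; the step is modest but beyond the scatter. It applies to one position, on a six-membered aromatic ring of carbon only, meta to a fused ring and para to a fused ring, and to this one pair. No measured evidence on hand bears on the origin of this step.

Going by these compounds, whether an amine, a carboxylic acid or a fluorine atom at this place would stand nearer to compound 2 or to compound 3 remains open. Also open, on these data alone, is whether the same change would give a similar step on the core of compound 1, whose differences from compound 2 and compound 3 in more than one place cannot be read as steps.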